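This account rests on a few compounds, and the source may have more. Where it says the series, first, only, none or still open, it means among the compounds named here.

Within the data shown here, compound 2 `COc1cc2cc(Oc3ccc(NC(=O)Nc4ccc(Cl)c(C(F)(F)F)c4)cc3)c(C)nc2cc1OC` is the only compound here with a measured number: in a functional assay on NCI-H322M cells (Homo sapiens) for inhibition, read by sulforhodamine B assay, with a stated time of 48 h (a higher number here means that more compound is tolerated, a lower number that less compound is tolerated), compound 2 gives 16300 nM. Compound 1 `COc1cc2cc(Oc3ccc(NC(=O)Nc4cccc(C(F)(F)F)c4)cc3)c(C)nc2cc1OC` gives in this assay only a limit and no number, > 50000 nM, so this compound sits at the limit of > 50000 nM in this assay, at which 1 of the 2 values shown sits. Among the measured compounds shown here, the single step on record, an at least 3.0-fold lower number from compound 1 to compound 2 (0.48 log units; beyond the scatter), adds a chloro group. Compound 3 `COc1cc2cc(Oc3ccc(NC(=O)Nc4ccc(Cl)c(Cl)c4)cc3)c(C)nc2cc1OC` differs from compound 2 by chloro in place of trifluoromethyl on an aromatic carbon. For the measured compounds named here, no measured step exchanges one of these two groups for the other, so the expected step of a 1.0-fold lower number from compound 2 to compound 3 (0.01 log units; within the scatter) stays within the scatter. Compound 3 is therefore estimated at 16000 nM, within 6000 nM to 45000 nM.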

Compound 3, concentration lethal to 50% of the cells: > 100000 nM
Compound 3: only a limit was reported; the forecaster's own chance of this, stated with the estimate: 15%; middle value at least 6.2-fold (0.79 log units) away from the limit.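

Trifluoromethyl, ortho to a chloro group, does not behave like a chloro group at this position: chloro in its place gives an at least 6.1-fold higher number from compound 2 to compound 3 (0.78 log units; beyond the scatter) in this assay, so the earlier gain from chloro does not carry over to this exchange. Compound 3 gives only a limit, > 100000 nM. The step from compound 1 to compound 3 cannot be read.

The compounds shown leave open how a methyl, a methoxy or a nitrile at this position would compare with trifluoromethyl. They also leave open whether this difference holds with other groups on the same ring.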